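This account rests on a few compounds, and the source may have more. Where it says the series, first, only, none or still open, it means among the compounds named here.

Two compounds sharing one core have been examined in an assay on isolated protein for displacement of a labelled ligand from 5-hydroxytryptamine receptor 6 (Homo sapiens); a lower number here means a stronger inhibitor, a higher number a weaker inhibitor. Compound 1 `NCC(=O)NC[C@@H]1CCCc2cc(S(=O)(=O)c3cccc(F)c3)ccc21` gives 0.316 nM. Compound 2 `COC(=O)NC[C@@H]1CCCc2cc(S(=O)(=O)c3cccc(F)c3)ccc21` gives 1.59 nM, which is the higher of the two numbers recorded so far. Among the measured compounds shown here, the only step between measured compounds is a 5.0-fold higher number from compound 1 to compound 2 (0.70 log units; beyond the scatter), a modest change that arose from exchanging the group on the carbonyl carbon.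

Compound 3 `CS(=O)(=O)NC[C@@H]1CCCc2cc(S(=O)(=O)c3cccc(F)c3)ccc21` is the next compound in line and differs from compound 2 by methylsulfonyl in place of methoxycarbonyl on an amine nitrogen. For the measured compounds named here, no measured pair tests this particular exchange directly. The step of a 5.0-fold higher number from compound 1 to compound 2 (0.70 log units; beyond the scatter) shows that the group attached to that nitrogen can shift this assay by a modest amount, but it swaps a different piece, so it serves only as a loose guide to the size of the effect. Against this background, compound 3 is expected to land near compound 2, with a step of a 1.3-fold higher number from compound 2 to compound 3 (0.10 log units; within the scatter) that may well remain within the usual scatter. For compound 3 the estimated value in this assay is 2 nM, with a range from 0.5 nM to 8 nM.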

Compound 3, inhibition constant: 0.2 nM
Estimate against measurement, compound 3: 10-fold (1.00 log units) above; measured number below the stated range.
By their numbers in this assay, from the lowest: compounds 3 and 1 (each within the scatter of the next); then compound 2.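

On the amine nitrogen, methylsulfonyl in place of methoxycarbonyl gives an 8.0-fold lower number from compound 2 to compound 3 (0.90 log units; beyond the scatter) in this assay. The two groups therefore differ clearly at this position, even though the computed counts of heavy atoms, hydrogen-bond donors and hydrogen-bond acceptors are the same for both, and the earlier step had not tested this exchange. The other new step, a 1.6-fold lower number from compound 1 to compound 3 (0.20 log units; within the scatter), lies within the scatter, so compound 3 and compound 1 cannot be told apart, which shows that the aminomethyl group of compound 1 is not required for a number at this level, and of the three compounds only compound 2 stands apart. No measurement offered here explains why the sulfonyl and carbamate groups differ.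

The three compounds leave open whether the result belongs to the methylsulfonyl group alone or extends to a larger group on the same nitrogen, such as ethylsulfonyl or phenylsulfonyl. They also leave open how a urea carbonyl group would compare at this position, and whether the step from methoxycarbonyl to methylsulfonyl would hold on any core other than the shared one.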